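From acetoxy to azido in a small series

A few compounds are considered here, and "the series" means these few. Any claim that something is new, unique, unknown or untested is made for them only; others in the source may bear on it.

Values so far in a functional assay on NCI-H460 cells (Homo sapiens); on this read-out higher numbers stand for an effect only at larger amounts of compound and lower numbers for an effect already at smaller amounts
Compound 1 `COc1cc(C2OC(c3ccc(N(C)C)cc3)=NN2C(C)=O)cc(OC)c1OC` gives 0.044 uM
Compound 2 `COc1cc(C2OC(c3ccc(N(C)C)cc3)=NN2C(=O)COC(C)=O)cc(OC)c1OC` gives 0.072 uM

Compound 2 at 0.072 uM lies within the scatter of compound 1 at 0.044 uM on these numbers, so the two cannot be ranked. Compound 3 `COc1cc(C2OC(c3ccc(N(C)C)cc3)=NN2C(=O)CN=[N+]=[N-])cc(OC)c1OC` is still unmeasured and carries azido in place of acetoxy on a saturated chain carbon bound to a carbonyl carbon, a change that counts out as azido in place of acetoxy on a saturated chain carbon bound to a carbonyl carbon in full. For the measured compounds named here, only one measured step bears on that carbon, hydrogen giving way to acetoxy, and with a 1.6-fold higher number from compound 1 to compound 2 (0.21 log units; within the scatter) as the sole guide, no shift beyond the scatter is expected in this assay for azido either. Going by the values given here, no azido compound has been measured, so this guide is indirect and the range is kept wide. The expected outcome is a 1.2-fold lower number from compound 2 to compound 3 (0.08 log units; within the scatter) in this read-out. For compound 3 the estimated value is 0.06 uM within an expected range of 0.02 uM to 0.2 uM for now.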

Compound 3, concentration for half-maximal effect: 0.53 uM
The estimate for compound 3 lay 8.8-fold (0.95 log units) below the measured number; the measured number lies above the stated range.
By their numbers in this assay, from the lowest: compounds 1 and 2 (each within the scatter of the next); then compound 3.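

In this assay, the saturated chain carbon bound to a carbonyl carbon proves sensitive to the group it carries: azido in place of acetoxy gives a 7.4-fold higher number from compound 2 to compound 3 (0.87 log units; beyond the scatter), and azido in place of hydrogen gives a 12-fold higher number from compound 1 to compound 3 (1.08 log units; beyond the scatter). For the compounds shown here, the only earlier step at this carbon, a 1.6-fold higher number from compound 1 to compound 2 (0.21 log units; within the scatter), stayed within the scatter, so the acetoxy result alone gave no sign that a substituent here could shift the number, and it does not carry over to azido. The data offer no measurement that accounts for the gap between azido and the other two compounds.

The three compounds leave open whether azido stands alone in raising the number at this carbon or whether an amine, a carboxylic acid or a longer chain in the same place would behave likewise. As far as these compounds go, they also share everything outside this chain, so it remains open whether the azido step would be of similar size on a different core or in a different read-out.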